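The compounds below may be only part of what the source reports. "The series", "measured", "known", "first", "only" and "open" are said of these compounds alone.

Measured in a physicochemical assay for solubility, read by nephelometry; a higher number here means a more soluble compound, a lower number a less soluble compound:
- Compound 1 `CN1CCN(CCCC(O)c2ccc(-c3ccc(N4C[C@H](Cn5ccnn5)OC4=O)cc3F)cn2)CC1`: > 400000 nM, a limit and not a number.
- Compound 2 `COCc1ccc(-c2ccc(N3C[C@H](Cn4ccnn4)OC3=O)cc2F)cn1`: 100000 nM.

Among the measured compounds shown here, compound 2 holds the only true number so far. For the measured compounds named here, the single measured step, an at least 4.0-fold lower number from compound 1 to compound 2 (0.60 log units; beyond the scatter), lies beyond the scatter and has a limit at one end, (the limit of > 400000 nM in this assay, at which 1 of the 2 values shown sits).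

Compound 3 `O=C(c1ccc(-c2ccc(N3C[C@H](Cn4ccnn4)OC3=O)cc2F)cn1)C1CCNCC1` has (piperidin-4-yl)carbonyl in place of methoxymethyl on an aromatic carbon, ((piperidin-4-yl)carbonyl in place of methoxymethyl on an aromatic carbon). Going by the values given here, only that one step bears on this change, and its group differs from the one entering here. Reading an at least 4.0-fold lower number from compound 1 to compound 2 (0.60 log units; beyond the scatter) in reverse, a rise in this assay is expected, though this is thin support. The expected step is a 2.5-fold higher number from compound 2 to compound 3 (0.40 log units; beyond the scatter). For compound 3 the estimate is 250000 nM, with an expected range from 100000 nM to 400000 nM.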

Compound 3, solubility: 100000 nM
The estimate for compound 3 lay 2.5-fold (0.40 log units) above the measured number, and the stated range covers the measured number.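

In this assay, (piperidin-4-yl)carbonyl in place of methoxymethyl next to the ring nitrogen shows no change at the digits printed from compound 2 to compound 3 (within the scatter) and so, at this position, a group with a non-aromatic ring and a hydrogen-bond donor reads the same as methoxymethyl. The 1-hydroxy-4-(4-methylpiperazin-1-yl)butyl group of compound 1 stays apart, with an at least 4.0-fold lower number from compound 1 to compound 3 (0.60 log units; beyond the scatter) as a second step of that kind. Compound 1 stands at a limit and not a number: the limit of > 400000 nM in this assay, at which 1 of the 3 values shown sits.

Open, from the compounds shown here alone, is which part of that chain carries the step. Also open, going by these compounds, is whether a carboxylic acid here would read differently from compound 2 and compound 3.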